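The compounds below may be only part of what the source reports. "The series", "measured", "known", "first", "only" and "open" are said of these compounds alone.

Measured compounds:
compound 1, `O=C(O)CCc1ccc(C#Cc2cccs2)cc1`: 251 nM
compound 2, `O=C(O)CCc1ccc(C#Cc2ccccn2)cc1`: 13200 nM
compound 3, `Cc1ccsc1C#Cc1ccc(CCC(=O)O)cc1`: 75.9 nM

In an in vitro functional assay on 1321-N1 cells for agonist activity at Free fatty acid receptor 1 (Homo sapiens), read by fluorescence, spectrophotometry and calcium flux (on this read-out higher numbers stand for an effect only at larger amounts of compound and lower numbers for an effect already at smaller amounts), compound 2 stands highest of the three: the nearest is compound 1, reached by a 53-fold higher number from compound 1 to compound 2 (1.72 log units; beyond the scatter), and the furthest is compound 3, reached by a 170-fold lower number from compound 2 to compound 3 (2.24 log units; beyond the scatter). Compound 4, `Cc1cccc(C#Cc2ccc(CCC(=O)O)cc2)n1`, differs from compound 2 by methyl in place of hydrogen on an aromatic carbon, next to the ring nitrogen and meta to a large group. Among the compounds with values here, the one measured step that bears on such a change is a 3.3-fold lower number from compound 1 to compound 3 (0.52 log units; beyond the scatter), where a methyl entered an aromatic carbon on a different ring. A step of similar size and direction is therefore expected, a 2.9-fold lower number from compound 2 to compound 4 (0.47 log units; beyond the scatter), so compound 4 is estimated at 4500 nM, within 1500 nM to 15000 nM.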

Compound 4, half-maximal effective concentration: 6170 nM
The estimate for compound 4 lay 1.4-fold (0.14 log units) below the measured number; the measured number falls inside the stated range.
By their numbers in this assay, from the lowest: compound 3; then compound 1; then compound 4; then compound 2.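

On the six-membered aromatic ring with 1 nitrogen, methyl in place of hydrogen next to the ring nitrogen gives a 2.1-fold lower number from compound 2 to compound 4 (0.33 log units; beyond the scatter). The same change thus lowers the number on this ring as well, and by a similar amount on both cores: the same change on two cores in this assay, a 3.3-fold lower number (0.52 log units; beyond the scatter) from compound 1 to compound 3 and a 2.1-fold lower number (0.33 log units; beyond the scatter) from compound 2 to compound 4, 1.5-fold (0.19 log units) apart, within the scatter of two such steps

The compounds shown leave open whether an ethyl, a methoxy or a chlorine at this position would give a step of the same direction and size. They also leave open whether a methyl on another carbon of this ring would do so.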